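This account rests on a few compounds, and the source may have more. Where it says the series, first, only, none or still open, it means among the compounds named here.

Measured so far in an assay on isolated protein for inhibition of Rho-associated protein kinase 1 (Homo sapiens), read by scintillation counting, radiometric assay and 33P incorporation, with a stated time of 40 min, in the presence of a further agent that is not named here; on this read-out lower numbers stand for stronger inhibition and higher numbers for weaker inhibition: compound 1 `COc1ccc(C(=O)Nc2cccc(NC(=O)COc3ccc4c(=O)ccoc4c3)c2)cc1` gives 18 nM; compound 2 `Cc1nc(C(=O)Nc2cccc(NC(=O)COc3ccc4c(=O)ccoc4c3)c2)cs1` gives 473 nM.

Within the data shown here, compound 2 stands highest of the two numbers; the only measured step, a 26-fold higher number from compound 1 to compound 2 (1.42 log units; beyond the scatter), is large. Compound 3 `Cn1ccc(S(=O)(=O)Nc2cccc(NC(=O)COc3ccc4c(=O)ccoc4c3)c2)n1` differs from compound 2 by a group of 9 heavy atoms (4 carbon, 2 nitrogen, 2 oxygen, 1 sulfur; one five-membered aromatic ring with 2 hetero atoms) in place of a group of 8 heavy atoms (5 carbon, 1 nitrogen, 1 oxygen, 1 sulfur; one five-membered aromatic ring with 2 hetero atoms), on a nitrogen on an aromatic ring. Among the measured compounds shown here, no measured step covers an exchange of this kind; the single step in this part of the molecule shows that the group there moves the numbers strongly, so a step beyond the scatter in either direction cannot be excluded, with no firm basis for one direction. Compound 3 is expected at about 600 nM, with a range of 150 nM to 2500 nM. The expected step is a 1.3-fold higher number from compound 2 to compound 3 (0.10 log units; within the scatter).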

Compound 3, half-maximal inhibitory concentration: > 10000 nM
Compound 3 gave a limit, no number (the forecaster's own chance of this, stated with the estimate: 10%); at least 16-fold (1.22 log units) between middle value and limit.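

In this assay compound 3 gives a limit and not a number: the limit of > 10000 nM in this assay, at which 1 of the 3 values shown sits. The group on the nitrogen can therefore do more than weaken inhibition by degrees: the exchange gives an at least 21-fold higher number from compound 2 to compound 3 (1.32 log units; beyond the scatter), and the span from the best compound is an at least 550-fold higher number from compound 1 to compound 3 (2.74 log units; beyond the scatter). Both steps replace the carbonyl-linked group with a sulfonyl-linked one and also change the ring, so the shown compounds do not separate the link from the ring. As far as these compounds go, how a 4-methoxyphenylsulfonyl group or a 2-methyl-1,3-thiazol-4-ylsulfonyl group on this nitrogen would read remains open.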